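Compound 1 to compound 3: tetrazole for carboxy

The compounds below may be only part of what the source reports. "The series", "measured", "known", "first", "only" and "open" are said of these compounds alone.

Values measured in a functional assay (aorta) for antagonist activity, with Oryctolagus cuniculus as the target (on this read-out higher numbers stand for weaker inhibition and lower numbers for stronger inhibition), are as follows
- compound 1 `CCCSC1=Nc2ccccc2S(=O)(=O)N1Cc1ccc(-c2ccccc2C(=O)O)cc1` gives 1200 nM
- compound 2 `CCCCC1=Nc2ccccc2S(=O)(=O)N1Cc1ccc(-c2ccccc2C(=O)O)cc1` gives 160 nM

Of the two, compound 1 stands higher at 1200 nM and so is the weaker inhibitor. Compound 3 `CCCSC1=Nc2ccccc2S(=O)(=O)N1Cc1ccc(-c2ccccc2-c2nn[nH]n2)cc1` has not yet been measured. It differs from compound 1 by 2H-tetrazol-5-yl in place of carboxy on an aromatic carbon with 2H-tetrazol-5-yl in place of carboxy on an aromatic carbon, ortho to a large group. Within the data shown here, no measured step touches that place, so the data offer no direct guide. Among the measured compounds shown here, the only measured step, a 7.5-fold lower number from compound 1 to compound 2 (0.88 log units; beyond the scatter), puts butyl in place of propylsulfanyl elsewhere in the structure. It bears on this change only as a measure of how far one swap has moved the number in these compounds. On that measure, a step of similar size towards a lower number is expected in this assay, though with wide uncertainty. For the measured compounds named here, the estimated change is a 6.0-fold lower number from compound 1 to compound 3 (0.78 log units; beyond the scatter) and no measurement yet supports it. For compound 3 the estimated value is 200 nM with an expected range of 40 nM to 1000 nM in this assay.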

Compound 3, antagonist equilibrium constant: 640 nM
Compound 3: the middle estimate sits 3.2-fold (0.51 log units) below what was measured; the range from low to high includes it.
By their numbers in this assay, from the lowest: compound 2; then compounds 3 and 1 (each within the scatter of the next).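

In this assay, 2H-tetrazol-5-yl in place of carboxy gives a 1.9-fold lower number from compound 1 to compound 3 (0.27 log units; within the scatter), so this swap leaves the two compounds within the usual scatter of each other. Among these compounds, this is the first reading at this place, on an aromatic carbon ortho to a large group, and it shows that in the propylsulfanyl compounds a five-membered aromatic ring with 4 hetero atoms can stand where carboxy stood without a change that repeated measurements could separate. Set beside the butyl for propylsulfanyl step, a 7.5-fold lower number from compound 1 to compound 2 (0.88 log units; beyond the scatter), which lies beyond the scatter, this swap is the one of the two that gives no readable change, and nothing shown here offers an explanation for how the two groups compare.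

The compounds shown leave open whether 2H-tetrazol-5-yl would also read alike with carboxy on the butyl compound, compound 2, where the swap might behave differently than it does with propylsulfanyl. They also leave open how other groups at this same place, such as an acylsulfonamide or a phosphonic acid, would compare with carboxy and 2H-tetrazol-5-yl.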